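Removing the phenoxy group from compound 2

The compounds below may be only part of what the source reports. "The series", "measured", "known", "first", "only" and "open" are said of these compounds alone.

In a functional assay on PC-3 cells (Homo sapiens) for antiproliferative activity, read by MTT assay, with a stated time of 48 h (a lower number here means a stronger inhibitor of growth, a higher number a weaker inhibitor of growth), compound 1 `CCCCCCCCN(Cc1ccc(C(=O)NO)cc1)c1ncc(-c2ccc(C)cc2)s1` gives 13300 nM and compound 2 `Cc1ccc(-c2cnc(N(CCCCOc3ccccc3)Cc3ccc(C(=O)NO)cc3)s2)cc1` gives 10300 nM on the same scale. Those two numbers lie within the usual scatter of each other, so compound 2 stands level with compound 1 and neither can be ranked above the other. Compound 3 `CCCCN(Cc1ccc(C(=O)NO)cc1)c1ncc(-c2ccc(C)cc2)s1` has not been measured yet. Measured against compound 2, the change is hydrogen in place of phenoxy on a saturated chain carbon, four bonds along the chain from a nitrogen on an aromatic ring and it puts hydrogen in place of phenoxy on a saturated chain carbon, four bonds along the chain from a nitrogen on an aromatic ring. Among the compounds with values here, one measured step bears on this, at the same place on the chain: a 1.3-fold lower number from compound 1 to compound 2 (0.11 log units; within the scatter) when phenoxy took the place of butyl. Within the data shown here, that step stayed within the scatter, but no tested compound shows the chain end simply removed, so the margins must stay wide. In this assay no change beyond the scatter is expected, and no firm direction. The estimated change is a 1.2-fold higher number from compound 2 to compound 3 (0.07 log units; within the scatter) in size and would stay within the scatter. Compound 3 is estimated at 12000 nM with an expected range from 5000 nM to 30000 nM in this measurement.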

Compound 3, concentration for 50% growth inhibition: 6410 nM
Beside the measured number, compound 3's estimate is 1.9-fold (0.27 log units) above it; the measured number falls inside the stated range.
By their numbers in this assay, from the lowest: compounds 3, 2 and 1 (each within the scatter of the next, the first and the last beyond it).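

In this assay, the phenoxy group can be removed from the chain end without a change that clears the usual scatter (with a 1.6-fold lower number from compound 2 to compound 3 (0.21 log units; within the scatter)), so compound 2 and compound 3 cannot be ranked against each other. Within the data shown here, the comparison with the longer chain of compound 1 does separate two compounds (with a 2.1-fold lower number from compound 1 to compound 3 (0.32 log units; beyond the scatter)): this is the first step at this position to lie beyond the scatter, though only modestly, and it suggests that the shorter butyl chain of compound 3 is tolerated at least as well as either longer chain end. Nothing measured here gives a reason for this small step, so the result remains a description of the numbers and not an explanation.

Still open, on these data alone, is whether a shorter chain, such as propyl or ethyl, would continue this modest trend or reverse it. It is also unclear how the number would respond to a chain ending in an amine or a carboxylic acid, since phenoxy is the only ring-bearing or oxygen-bearing end shown here.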